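Swapping phenyl for benzofuranyl on a weak nucleoside

The compounds below may be only part of what the source reports. "The series", "measured", "known", "first", "only" and "open" are said of these compounds alone.

Compound 2 `O=c1[nH]cnc2c1c(-c1ccccc1)cn2[C@@H]1O[C@H](CO)[C@@H](O)[C@H]1O` gives > 100000 nM in a functional assay on A549 cells (Homo sapiens), read by MTT assay, with a stated time of 72 h (a lower number here means a stronger inhibitor, a higher number a weaker inhibitor), which is a limit of the assay and not a number. It therefore stands at the limit of > 100000 nM in this assay, at which 1 of the 2 values shown sits. Compound 3 `O=c1[nH]cnc2c1c(-c1cc3ccccc3o1)cn2[C@@H]1O[C@H](CO)[C@@H](O)[C@H]1O` differs from compound 2 by one change 1-benzofuran-2-yl in place of phenyl on an aromatic carbon. For the measured compounds named here, no measured pair shows this change directly. The nearest guide is compound 1 `COc1ncnc2c1c(-c1cc3ccccc3o1)cn2[C@@H]1O[C@H](CO)[C@@H](O)[C@H]1O`, which also bears 1-benzofuran-2-yl and gives 17700 nM in this assay. On the strength of compound 1 at 17700 nM, a modest shift towards stronger inhibition is expected in this assay. The expected change is an at least 1.6-fold lower number from compound 2 to compound 3 (0.22 log units; that floor lies within the scatter). For compound 3 the estimated half-maximal inhibitory concentration is 60000 nM, within an expected range of 20000 nM to 100000 nM.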

Compound 3, half-maximal inhibitory concentration: > 20000 nM
Compound 3 ended at the assay's limit; the forecaster's own chance of this, stated with the estimate: 55%; the middle value is on the limit's open side.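

For the compounds shown here, compound 2 and compound 3 both ended at limits of this assay, so no step between them can be read. The compounds shown leave open whether 1-benzofuran-2-yl in place of phenyl on an aromatic carbon changes the half-maximal inhibitory concentration, and in which direction.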